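Swapping the aryl group on the pyrazole nitrogen

The source may hold more compounds than are shown below. What is called first, only, known or untested is meant among the compounds shown, and "the series" means these compounds.

Measured compounds:
compound 1 `Cc1ccccc1NC(=O)c1cnn(-c2ccc(F)cc2)c1C` gives 1100 nM;
compound 2 `CCCCC(CC)NC(=O)c1cnn(-c2ccc(F)cc2)c1C` gives 580 nM;
compound 3 `COc1ccc(-n2ncc(C(=O)Nc3ccc(C(F)(F)F)cc3)c2C)cc1` gives 340 nM.

In a functional assay with Homo sapiens as the target (on this read-out higher numbers stand for weaker inhibition and lower numbers for stronger inhibition), compound 3 stands lowest of the three, though its gap to compound 2 lies within the scatter; only compound 1 sits clearly higher. Compound 4 `Cc1cccc(-n2ncc(C(=O)Nc3ccc(C(F)(F)F)cc3)c2C)c1` differs from compound 3 by 3-methylphenyl in place of 4-methoxyphenyl on an aromatic nitrogen. Going by the values given here, the single measured step, a 1.9-fold lower number from compound 1 to compound 2 (0.28 log units; within the scatter), concerns the amide-type nitrogen, not the aromatic nitrogen, so no step bears on this change. Compounds 1 and 2 share a different aryl group at this position but also differ elsewhere, so their values do not isolate it. Compound 4 is therefore expected to give 420 nM, between 150 nM and 1200 nM, a step of a 1.2-fold higher number from compound 3 to compound 4 (0.09 log units; within the scatter) that is estimated to stay within the scatter.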

Compound 4, half-maximal inhibitory concentration: 2500 nM
Beside the measured number, compound 4's estimate is 6.0-fold (0.77 log units) below it, outside the stated range (above it).
By their numbers in this assay, from the lowest: compounds 3, 2 and 1 (each within the scatter of the next, the first and the last beyond it); then compound 4.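

Going by these compounds alone, the aryl group on the aromatic nitrogen proves able to move the number in this assay: with the amide side held constant, 3-methylphenyl in place of 4-methoxyphenyl gives a 7.4-fold higher number from compound 3 to compound 4 (0.87 log units; beyond the scatter), the only step here that isolates this position. The earlier compounds shown here offered no such comparison, and the change removes the one hydrogen-bond acceptor of the leaving group. No measurement shown explains the step. The two aryl groups differ in both substituent and its place on the ring, so these effects remain unseparated. From the compounds shown here alone, how a plain phenyl or a hydroxyl-bearing phenyl would compare stays open.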